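Swapping 2-(trifluoromethyl)phenyl for 3-(trifluoromethyl)phenyl

This account rests on a few compounds, and the source may have more. Where it says the series, first, only, none or still open, it means among the compounds named here.

In an ADME assay (liver) for metabolic stability, with Liver microsome (Canis lupus familiaris) as the target, read by LC-MS, using microsomes, with a stated time of 30 min, tested at 4 uM (on this read-out higher numbers stand for a more stable compound and lower numbers for a less stable compound), compound 3 (`Cc1nc(N2CCN(C)CC2)c2nc(-c3ccccc3C(F)(F)F)n(C3CCOCC3)c2n1`) gives 61%. Compound 1 (`Cc1nc(N2CCN(C)CC2)c2nc(-c3ccccc3Cl)n(CCN3CCCC3=O)c2n1`) gives 60%, which lies within the usual scatter of compound 3, so the two cannot be told apart on this read-out. Compound 2 (`Cc1nc(N2CCN(C)CC2)c2nc(-c3cccc(Cl)c3)n(C3CCOCC3)c2n1`) gives 45%, a clearly lower number.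

The next structure, compound 4 (`Cc1nc(N2CCN(C)CC2)c2nc(-c3cccc(C(F)(F)F)c3)n(C3CCOCC3)c2n1`), has the same atoms as compound 3, joined differently: 3-(trifluoromethyl)phenyl in place of 2-(trifluoromethyl)phenyl on an aromatic carbon. The change sits on an aromatic carbon of a five-membered aromatic ring with 2 nitrogen, next to the ring atom that bears an oxan-4-yl group.

Going by the values given here, only one measured step bears on this change: a number 16 percentage points higher from compound 2 to compound 3 (beyond the scatter). That step replaces 3-chlorophenyl with 2-(trifluoromethyl)phenyl, so it is only an indirect guide. Compound 4 has a 3-substituted phenyl group, as compound 2 does, and compound 2 stands at 45%. A return of most of the way towards that value therefore seems likely, though the data cannot confirm it. The expected change is modest and downward: a number 11 percentage points lower from compound 3 to compound 4 (beyond the scatter). For compound 4 the estimated value is 50%, with an expected range from 37% to 63%.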

Compound 4, percent of the compound remaining: 44%
Estimate against measurement, compound 4: 6 percentage points above; the measured number falls inside the stated range.
By their numbers in this assay, from the lowest: compounds 4 and 2 (each within the scatter of the next); then compounds 1 and 3 (each within the scatter of the next).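

In this assay the place of the trifluoromethyl group on the phenyl ring matters on its own: with the same atoms joined differently, the result is (a number 17 percentage points lower from compound 3 to compound 4 (beyond the scatter)). Keeping 3-substituted phenyl and putting trifluoromethyl in place of chloro gives no readable change (a number 1 percentage points lower from compound 2 to compound 4 (within the scatter)), so the earlier step (a number 16 percentage points higher from compound 2 to compound 3 (beyond the scatter)), which changed both the group and its place, can now be read more clearly: among these three compounds the number follows the place on the phenyl ring, not the choice between chloro and trifluoromethyl. Nothing measured here explains why the two placements differ.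

Going by these compounds, whether the higher number of 2-(trifluoromethyl)phenyl carries over to other groups on the phenyl ring, such as a nitrile or a methoxy group, stays open. Going by these compounds alone, it is equally open whether the gap between the two placements would persist if the oxan-4-yl group gave way to an amine or a longer chain, as only this one group is compared here.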